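What One Cyclopropyl Group May Do to Solubility

The source may report more compounds than this note shows. Statements on the series, on what has been measured and on what is new or still open speak of the compounds shown alone.

Solubility, how much of a compound stays dissolved, is the question here, and two compounds have numbers in a physicochemical assay for solubility, read by HPLC, using the shake flask method, in phosphate buffer, measured as kinetic solubility, with a stated time of 20 h, at pH 6.5 (a lower number here means a less soluble compound, a higher number a more soluble compound), so far. Compound 1 `Fc1ccc(Nc2cc3[nH]c(Nc4ccc(N5CCN(CC6CC6)CC5)cn4)nc3cn2)cc1C(F)(F)F` reads 75000 nM and compound 2 `C[C@@H]1CN(C(=O)c2ccnc(Nc3nc4cnc(-c5ccc(F)c(C(F)(F)F)c5)cc4[nH]3)c2)C[C@H](C)N1C` reads 180000 nM as the higher of the two numbers, a gap beyond the usual scatter of repeat measurements.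

Compound 3 `C[C@@H]1CN(C(=O)c2ccnc(Nc3nc4cnc(-c5ccc(F)c(C(F)(F)F)c5)cc4[nH]3)c2)C[C@H](C)N1CC1CC1` has not yet been measured. Its structure departs from compound 2 at one place: cyclopropyl in place of hydrogen on a saturated chain carbon bound to an amine nitrogen in a ring with cyclopropyl in place of hydrogen on a saturated chain carbon bound to an amine nitrogen in a ring, which turns methyl to cyclopropylmethyl.

Among the measured compounds shown here, no measured pair shows this change alone, so the evidence is thin. Compound 1 also carries a cyclopropylmethyl group and reads the lower number (75000 nM) but it differs from compound 2 in other places too. A modest fall, just beyond the scatter, is expected in this assay (a 2.3-fold lower number from compound 2 to compound 3 (0.35 log units; beyond the scatter) as estimated). The estimate for compound 3 is 80000 nM with an expected range of 25000 nM to 170000 nM in the coming measurement.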

Compound 3, solubility: 200000 nM
Compound 3: middle estimate off by 2.5-fold (0.40 log units), on the low side; the measured number lies above the stated range.
By their numbers in this assay, from the lowest: compound 1; then compounds 2 and 3 (each within the scatter of the next).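

Among the compounds shown here, compound 2 and compound 3 form the first measured pair that holds this change alone: methyl becomes cyclopropylmethyl, which turns 3,4,5-trimethylpiperazin-1-yl into 4-(cyclopropylmethyl)-3,5-dimethylpiperazin-1-yl, while the rest of the structure stays the same. In this assay the pair gives a 1.1-fold higher number from compound 2 to compound 3 (0.05 log units; within the scatter) as its step, so with or without the cyclopropyl ring, the two numbers lie within the scatter of each other on this core. For the compounds shown here, at this position, then, cyclopropyl in place of hydrogen on a saturated chain carbon bound to an amine nitrogen in a ring need not come with a lower number in this assay, although a single pair gives only one reading.

Nothing measured here tells why the two numbers sit so close. Still open, as far as these compounds go, is how a longer chain such as butyl, a 2-hydroxyethyl group or an acetyl group would read in this assay in place of the cyclopropylmethyl group, and whether the same change would read alike on the core of compound 1.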